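Sulfamoyl Amine Variation on a Piperidine Carboxamide Series

This account rests on a few compounds, and the source may have more. Where it says the series, first, only, none or still open, it means among the compounds named here.

Three compounds share one core and differ only in the group on the aromatic carbon. In a functional assay on MIA PaCa-2 cells (Homo sapiens) for inhibition, read by MTT assay, with a stated time of 7 days (a lower number here means a stronger inhibitor, a higher number a weaker inhibitor), compound 1 `CCN(CC)C(=O)c1ccc(S(=O)(=O)N2CCC[C@@H](C(=O)N3CCC(F)(F)CC3)C2)cc1` gives 70 nM, compound 2 `CN(C)S(=O)(=O)c1ccc(S(=O)(=O)N2CCC[C@@H](C(=O)N3CCC(F)(F)CC3)C2)cc1` gives 118 nM, and compound 3 `CCN(CC)S(=O)(=O)c1ccc(S(=O)(=O)N2CCC[C@@H](C(=O)N3CCC(F)(F)CC3)C2)cc1` gives 16 nM, the lowest number of the three. Among the measured compounds shown here, the step of a 7.4-fold lower number from compound 2 to compound 3 (0.87 log units; beyond the scatter) is the one that bears on compound 4 `CC(C)NS(=O)(=O)c1ccc(S(=O)(=O)N2CCC[C@@H](C(=O)N3CCC(F)(F)CC3)C2)cc1`, which differs from compound 3 by isopropylamino in place of diethylamino on a sulfonyl sulfur. Because a 7.4-fold lower number from compound 2 to compound 3 (0.87 log units; beyond the scatter) shows that a smaller amine on the sulfonyl sulfur went with a higher number, a higher number is expected for compound 4, though the isopropylamino group is closer in size to diethylamino than dimethylamino is, so the expected step of a 2.8-fold higher number from compound 3 to compound 4 (0.45 log units; beyond the scatter) is smaller. Compound 4 is estimated at 45 nM, between 15 nM and 150 nM.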

Compound 4, half-maximal inhibitory concentration: 350 nM
For compound 4 the middle estimate is 7.8-fold (0.89 log units) below the measured one; measured number above the stated range.
By their numbers in this assay, from the lowest: compound 3; then compounds 1 and 2 (each within the scatter of the next); then compound 4.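

At this sulfonyl sulfur the number does not simply follow amine size: the step is large, a 22-fold higher number from compound 3 to compound 4 (1.34 log units; beyond the scatter), and the earlier trend fails with a 3.0-fold higher number from compound 2 to compound 4 (0.47 log units; beyond the scatter). Compound 4 also falls behind the carboxamide, with a 5.0-fold higher number from compound 1 to compound 4 (0.70 log units; beyond the scatter). Isopropylamino carries a hydrogen-bond donor that diethylamino lacks, but no data here explain the step.

Still open, as far as these compounds go, is whether the amine hydrogen or the branched chain goes with the higher number; an ethylamino or a methyl(isopropyl)amino group on the same sulfur would help separate the two.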